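The compounds below may be only part of what the source reports. "The series", "measured", "known", "first", "only" and "open" are said of these compounds alone.

Compound 1 `N=C(S)CCCn1nc(-c2ccccc2)ccc1=O` is the starting point of this account. In a functional assay on the whole organism (gastric juice) with Rattus norvegicus as the target (on this read-out lower numbers stand for an effect already at smaller amounts and higher numbers for an effect only at larger amounts of compound), compound 1 gives 15.5 mg/kg, the lowest of the two numbers in hand. For the measured compounds named here, the only other measured compound, compound 2 `Cc1ccc(=O)n(CCC(=N)S)n1`, gives in this assay 51.3 mg/kg, a higher number; the two differ in more than one place, so their gap is reported only as what the two values show and not as a single step. Compound 3 `CC(Cn1nc(-c2ccccc2)ccc1=O)C(=N)S` has the same atoms as compound 1 joined differently: a group of 5 heavy atoms (3 carbon, 1 nitrogen, 1 sulfur; no ring) in place of a group of 5 heavy atoms (3 carbon, 1 nitrogen, 1 sulfur; no ring), on a saturated chain carbon bound to an aromatic nitrogen. Going by the values given here, no measured pair shows the effect of such a rearrangement of the chain, so any expectation rests on the values at hand alone. A modest step is expected in this assay, most likely toward a somewhat higher number, though possibly none beyond the scatter. Compound 3 is therefore estimated at 22 mg/kg, with a range from 9 mg/kg to 55 mg/kg. That estimate means an expected step of a 1.4-fold higher number from compound 1 to compound 3 (0.15 log units; within the scatter).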

Compound 3, dose for half-maximal effect: 18.2 mg/kg
Beside the measured number, compound 3's estimate is 1.2-fold (0.08 log units) above it, within the range that was stated.
By their numbers in this assay, from the lowest: compounds 1 and 3 (each within the scatter of the next); then compound 2.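

In this assay, putting one group of 5 heavy atoms in place of another with the same atoms, on a saturated chain carbon bound to an aromatic nitrogen, gives a 1.2-fold higher number from compound 1 to compound 3 (0.07 log units; within the scatter). For the compounds shown here, this is the first step in the account that differs in one place only, and it shows that this rearrangement of the chain leaves the two compounds within the scatter of each other, so that they cannot be told apart on this read-out. Nothing at hand offers an explanation for this result.

The compounds shown leave open whether this place would tolerate a change that alters the atoms themselves, such as a longer chain, an amine or a carboxylic acid. They also leave open whether the same rearrangement would give a similar result on a core other than that of compound 1.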